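This account rests on a few compounds, and the source may have more. Where it says the series, first, only, none or still open, it means among the compounds named here.

Of the compounds shown here, three built on one shared core have been tested in a functional assay on BGC-823 cells (Homo sapiens) for cytotoxicity, read by MTT assay, with a stated time of 48 h (on this read-out higher numbers stand for weaker inhibition and lower numbers for stronger inhibition), where the compounds differ only in the ring that hangs from the far end of the molecule. Compound 1, `O=C(CSc1nnc(-c2ccncc2)o1)N/N=C/c1ccccc1`, gives 22100 nM. Compound 2, `O=C(CSc1nnc(-c2ccncc2)o1)N/N=C/c1ccc(Cl)cc1`, gives 20500 nM in this assay. Compound 3, `O=C(CSc1nnc(-c2ccncc2)o1)N/N=C/c1ccccc1O`, gives 6160 nM in this assay.

The change from compound 1 to compound 2 is chloro in place of hydrogen on an aromatic carbon, and it produced a 1.1-fold lower number from compound 1 to compound 2 (0.03 log units; within the scatter). Going from compound 1 to compound 3 produced a 3.6-fold lower number from compound 1 to compound 3 (0.55 log units; beyond the scatter), and the same thing seen from the other side is a 3.3-fold lower number from compound 2 to compound 3 (0.52 log units; beyond the scatter). Compound 3 thus stands lowest of the three, with both steps leading to it beyond the scatter.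

The unmeasured compound 4, `O=C(CSc1nnc(-c2ccncc2)o1)N/N=C/c1cc(Cl)ccc1O`, carries chloro in place of hydrogen on an aromatic carbon. Within the data shown here, this is the same kind of change as the one from compound 1 to compound 2, but not the same: there the chlorine entered para to a large group, whereas here it enters meta to a large group and para to a hydroxy group. The two cores themselves differ by hydroxy in place of hydrogen on an aromatic carbon.

Because a 1.1-fold lower number from compound 1 to compound 2 (0.03 log units; within the scatter) stayed within the scatter, the expected step of a 1.1-fold lower number from compound 3 to compound 4 (0.05 log units; within the scatter) is taken to be similarly small. Compound 4 is therefore estimated at 5500 nM, with a likely range from 2500 nM to 12000 nM.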

Compound 4, half-maximal inhibitory concentration: 5470 nM
For compound 4 the middle estimate is 1.0-fold (0.00 log units) above the measured one; low and high end bracket the measured number.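

Chloro in place of hydrogen on the core of compound 3 gave a 1.1-fold lower number from compound 3 to compound 4 (0.05 log units; within the scatter), and in this assay the same change reads alike on the two cores: the same change on two cores in this assay, a 1.1-fold lower number (0.03 log units; within the scatter) from compound 1 to compound 2 and a 1.1-fold lower number (0.05 log units; within the scatter) from compound 3 to compound 4, 1.0-fold (0.02 log units) apart, within the scatter of two such steps

So the chloro change carried from the core of compound 1 to the core of compound 3 without a step beyond the scatter on either, and compound 4 stands apart from the two compounds without a hydroxy group, with a 3.7-fold lower number from compound 2 to compound 4 (0.57 log units; beyond the scatter) and a 4.0-fold lower number from compound 1 to compound 4 (0.61 log units; beyond the scatter). Among these compounds, this rests on only two pairs, with the chlorine in a different place in each (para to a hydroxy group in compound 4), so it does not show that chloro would give so small a step at other places on the ring, on other cores or in other cells.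

The compounds shown leave open whether another group in the chlorine's place, such as methoxy, an amine or a carboxylic acid, would give a larger step on either core. They also leave open whether the hydroxy group itself could be exchanged, for example for methoxy or an amine, and still give a number as low as those of compound 3 and compound 4.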